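A Second Methyl on the Shared Core: What to Expect

This account rests on a few compounds, and the source may have more. Where it says the series, first, only, none or still open, it means among the compounds named here.

For the measured compounds named here, compound 2 `CCCCCCCCCCC1(C(=O)Nc2c(C)ccc3c2OC(C)(C)C3)CCCC1` gives 240 nM in an assay for inhibition of acyl-CoA:cholesterol acyltransferase (Oryctolagus cuniculus), using microsomes (on this read-out lower numbers stand for stronger inhibition and higher numbers for weaker inhibition), the lower of the two numbers measured so far; compound 1 `CCCCCCCCCCC1(C(=O)Nc2cccc3c2OC(C)(C)C3)CCCC1` gives 500 nM. Compound 3 `CCCCCCCCCCC1(C(=O)Nc2c(C)cc(C)c3c2OC(C)(C)C3)CCCC1` has not been measured yet. It differs from compound 2 by methyl in place of hydrogen on an aromatic carbon. Going by the values given here, the one measured step that bears on this change, a 2.1-fold lower number from compound 1 to compound 2 (0.32 log units; beyond the scatter), was also a methyl added to an aromatic carbon. On that basis a further modest drop is expected, though the new methyl sits at a different place, so the step of a 1.4-fold lower number from compound 2 to compound 3 (0.15 log units; within the scatter) is estimated to be small. Compound 3 is expected to give about 170 nM, within 70 nM to 400 nM.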

Compound 3, half-maximal inhibitory concentration: 170 nM
For compound 3 middle estimate and measured number coincide at the digits printed; the range from low to high includes it.
By their numbers in this assay, from the lowest: compounds 3 and 2 (each within the scatter of the next); then compound 1.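

In this assay a methyl in place of hydrogen at this position, para to a large group, gives a 1.4-fold lower number from compound 2 to compound 3 (0.15 log units; within the scatter) and so cannot be told apart from the measured scatter. The same change at the earlier position gave a step beyond the scatter, so this change does not bring a clear gain at every aromatic carbon of the shared core. Nothing measured here explains why the two positions differ. Still open, going by these compounds, is whether a different group at this position, such as an amine or a methoxy group, would give a number clearly apart from that of compound 2.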